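The source may report more compounds than this note shows. Statements on the series, on what has been measured and on what is new or still open speak of the compounds shown alone.

In a functional assay on A549 cells (Homo sapiens) for antiproliferative activity, read by MTT assay, with a stated time of 72 h (a lower number here means a stronger inhibitor, a higher number a weaker inhibitor), compound 2 (`O=C1COc2ccc(-c3cccc(NS(=O)(=O)c4ccc(F)cc4)c3)cc2N1`) gives 32100 nM. Within the data shown here, the only other compound measured so far, compound 1 (`O=C1COc2ccc(-c3cnc(Cl)c(NS(=O)(=O)c4ccc(F)cc4)c3)cc2N1C1CCCCC1`), gives 37900 nM. These two numbers lie within the usual scatter of repeated measurements, so they cannot be ranked and compound 2 simply stands level with compound 1.

The next compound, compound 3 (`CC(C)N1C(=O)COc2ccc(-c3cccc(NS(=O)(=O)c4ccc(F)cc4)c3)cc21`), differs from compound 2 in one place: isopropyl in place of hydrogen on an amide-type nitrogen in a ring. Among the measured compounds shown here, no two measured compounds differ in just one place, so the data give no direct reading of what a single change does in this assay. For the measured compounds named here, the only guide is the level already seen, with compound 1 at 37900 nM and compound 2 at 32100 nM. Nothing here points up or down, so the expectation is for no shift beyond the scatter. The expected change is small, an estimated 1.1-fold lower number from compound 2 to compound 3 (0.03 log units; within the scatter). For compound 3 the estimated value is 30000 nM, with an expected range from 12000 nM to 65000 nM.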

Compound 3, half-maximal inhibitory concentration: 29400 nM
Compound 3: the middle estimate sits 1.0-fold (0.01 log units) above what was measured; low and high end bracket the measured number.
By their numbers in this assay, from the lowest: compounds 3, 2 and 1 (each within the scatter of the next).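

Among these compounds, this is the first pair of compounds that differ in one place, so this assay can now be read for a single change: replacing the hydrogen on the amide-type nitrogen of compound 2 with isopropyl gives a 1.1-fold lower number from compound 2 to compound 3 (0.04 log units; within the scatter). The entering group adds 3 heavy atoms, all carbon, to a nitrogen that held no heavy atom in compound 2, yet the two numbers cannot be told apart, so this position accepts isopropyl with no shift that this assay can resolve. No measurement at hand bears on why the number stays level with this change.

Among the compounds shown here, this single step covers only one small carbon group at one position, so it does not show that every group would be accepted on this nitrogen. As far as these compounds go, whether a longer chain, an amine or a carboxylic acid placed on the same nitrogen would also leave the number level, or would move it beyond the scatter, stays open.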